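Aryl swap on compound 2 in the cytotoxicity series

The source may hold more compounds than are shown below. What is called first, only, known or untested is meant among the compounds shown, and "the series" means these compounds.

Three compounds of the series carry numbers in a functional assay on Pfeiffer cells (Homo sapiens) for cytotoxicity, read by scintillation counting and thymidine incorporation, with a stated time of 4 days; on this read-out lower numbers stand for stronger inhibition and higher numbers for weaker inhibition. Compound 1 `COc1c([C@H](C)Nc2ncnc(N)c2C#N)cc(Cl)c(C)c1-c1ccc(C(=O)N(C)C)cn1` gives 61 nM. Compound 3 `C[C@H](Nc1ncnc2[nH]cnc12)c1cc(Cl)c2cccnc2c1-c1cccc(F)c1` gives 1000 nM. Compound 2 `COc1c([C@H](C)Nc2ncnc3[nH]cnc23)cc(Cl)c(C)c1-c1ccc(S(C)(=O)=O)cc1` gives 3100 nM, the highest of the three numbers; compound 3 is its nearest neighbour and compound 1 its furthest, and both gaps lie beyond the usual scatter.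

Compound 4 `COc1c([C@H](C)Nc2ncnc3[nH]cnc23)cc(Cl)c(C)c1-c1cnn(C)c1` is not yet measured. It differs from compound 2 in one place: 1-methyl-1H-pyrazol-4-yl in place of 4-(methylsulfonyl)phenyl on an aromatic carbon. The new group sits on an aromatic carbon of a six-membered aromatic ring of carbon only, ortho to a methoxy group and ortho to a methyl group.

Among the compounds with values here, no pair of measured compounds isolates this kind of change, so the direction cannot be read from the data. Compounds 1 and 3 vary in more than one place at once, and neither carries the entering group. The expectation for the step from compound 2 to compound 4 is a small one, a 1.6-fold lower number from compound 2 to compound 4 (0.19 log units; within the scatter), toward a lower number but possibly not beyond the scatter. Compound 4 is therefore estimated at 2000 nM in this assay, within 600 nM to 6500 nM.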

Compound 4, half-maximal inhibitory concentration: 950 nM
Compound 4: the middle estimate sits 2.1-fold (0.32 log units) above what was measured, within the range that was stated.
By their numbers in this assay, from the lowest: compound 1; then compounds 4 and 3 (each within the scatter of the next); then compound 2.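

In this assay this position is shown to respond to the group it carries: 1-methyl-1H-pyrazol-4-yl in place of 4-(methylsulfonyl)phenyl gives a 3.3-fold lower number from compound 2 to compound 4 (0.51 log units; beyond the scatter) on an otherwise unchanged compound. Both groups count 0 hydrogen-bond donors and 2 hydrogen-bond acceptors, so the step comes without a change in those counts, while the heavy atoms become fewer and a five-membered aromatic ring with 2 hetero atoms replaces a six-membered aromatic ring of carbon only. No measurement at hand bears on what lies behind the step.

Still open, as far as these compounds go, is how an unsubstituted phenyl or a 1H-pyrazol-4-yl lacking the methyl group would read at this position. Such groups would help separate the contribution of the ring from that of the methylsulfonyl or methyl substituent.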